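The source may hold more compounds than are shown below. What is called first, only, known or untested is meant among the compounds shown, and "the series" means these compounds.

Compound 1 `CC(O)(CSc1cccc(C(F)(F)F)c1)C(=O)Nc1ccc(S(F)(F)(F)(F)F)cc1`: 26200 nM
Compound 2 `CC(O)(COc1cccc(S(F)(F)(F)(F)F)c1)C(=O)Nc1ccc(C#N)cc1C(F)(F)F`: 16300 nM

In a functional assay on DU-145 cells (Homo sapiens) for antiproliferative activity, read by propidium iodide staining, with a stated time of 96 h (on this read-out higher numbers stand for weaker inhibition and lower numbers for stronger inhibition), compound 2 gives 16300 nM, which lies within the usual scatter of compound 1 at 26200 nM. The two values therefore cannot be ranked. Compound 3 `CC(O)(COc1cccc(S(F)(F)(F)(F)F)c1)C(=O)Nc1ccc([N+](=O)[O-])cc1C(F)(F)F` keeps the rest of compound 2 but has nitro in place of cyano on an aromatic carbon. Among the measured compounds shown here, no measured pair shows what this swap does, so no change beyond the scatter is expected in this assay. The estimated step is a 1.1-fold lower number from compound 2 to compound 3 (0.04 log units; within the scatter). The expected value for compound 3 is 15000 nM, within an estimated range of 6000 nM to 38000 nM.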

Compound 3, half-maximal inhibitory concentration: 18000 nM
Beside the measured number, compound 3's estimate is 1.2-fold (0.08 log units) below it, within the range that was stated.
By their numbers in this assay, from the lowest: compounds 2, 3 and 1 (each within the scatter of the next).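

With nitro in place of cyano on an aromatic carbon, para to a large group and meta to a trifluoromethyl group, this assay shows a 1.1-fold higher number from compound 2 to compound 3 (0.04 log units; within the scatter) and so the two groups cannot be told apart at this position. This pair is the only one here that isolates a single place on the molecule. No measurement shown here offers a reason for this result.

Going by these compounds, whether an amine or a carboxylic acid at this position would move the number beyond the scatter stays open. So does whether nitro and cyano would also match on a different core.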